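Removing the Acetyl Group from Compound 3

The compounds below may be only part of what the source reports. "The series", "measured", "known", "first", "only" and "open" are said of these compounds alone.

In an ADME assay on TZM-b1 cells (Homo sapiens) for cytotoxicity, read by XTT assay, with a stated time of 3 days (on this read-out higher numbers stand for lower toxicity in this test and lower numbers for higher toxicity in this test), compound 3 `CC(=O)N1CCCCC1C(NC(=O)C(=O)Nc1ccc(Cl)cc1)c1nc(C)c(CCO)s1` gives > 84000 nM, which is a limit of the assay and not a number. For the measured compounds named here, no measured compound in this small set has a number here, so compound 3 cannot be ranked against the others. Compound 4 `Cc1nc(C(NC(=O)C(=O)Nc2ccc(Cl)cc2)C2CCCCN2)sc1CCO` differs from compound 3 in one place: hydrogen in place of acetyl on an amine nitrogen in a ring.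

Going by the values given here, no measured step covers this change. The only one, a step that the two limits leave unreadable from compound 1 to compound 2, lies on an amide-type nitrogen and offers no size to carry over. The nearest guidance comes from two compounds that differ from compound 4 elsewhere but share its piperidin-2-yl. Compound 1 `Cc1nc(C(NC(=O)C(=O)Nc2ccc(F)c(Cl)c2)C2CCCCN2)sc1CO` gives > 77800 nM in this assay, also a limit. Compound 2 `Cc1ccc(NC(=O)C(=O)NC(c2nc(C)c(CO)s2)C2CCCCN2)c(F)c1` gives > 88000 nM, again a limit.

On that basis, no change beyond the usual scatter is expected, and the estimated step is a step that the limit leaves unreadable from compound 3 to compound 4. Compound 4 is expected to give 85000 nM, with an estimated range from 40000 nM to 100000 nM.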

Compound 4, half-maximal cytotoxic concentration: 32800 nM
Compound 4: middle estimate off by 2.6-fold (0.41 log units), on the high side, outside the stated range (below it).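

Hydrogen in place of acetyl on an amine nitrogen in a ring gives the first readable step in this set: in this assay, there is an at least 2.5-fold lower number from compound 3 to compound 4 (0.40 log units; beyond the scatter). This shows that the change from 1-acetylpiperidin-2-yl to piperidin-2-yl can move this read-out beyond the usual scatter, and compound 4 is the only compound shown with a number rather than a limit. The true size of the step stays unknown, since the value for compound 3 is a limit of the assay and not a number: the limit of > 84000 nM in this assay, at which 1 of the 4 values shown sits.

The compounds shown leave open whether a methyl group or a longer acyl chain on this nitrogen would read like acetyl or like hydrogen. They also leave open whether acetyl on this nitrogen would produce a similar step in compound 1 or compound 2.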